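This account rests on a few compounds, and the source may have more. Where it says the series, first, only, none or still open, it means among the compounds named here.

Notes on the series in a functional assay on COLO 205 cells (Homo sapiens) for cytotoxicity; a lower number here means a stronger inhibitor, a higher number a weaker inhibitor. Compound 1 `COc1ccc(-n2nc(Nc3cc(C)[nH]n3)c3ccccc3c2=O)cc1` gives 3700 nM, the second highest of the three numbers gathered so far. Going by the values given here, compound 2 `Cc1cc(Nc2nn(-c3ccc(F)cc3)c(=O)c3ccccc23)n[nH]1` gives 1600 nM, and the step of a 2.3-fold lower number from compound 1 to compound 2 (0.36 log units; beyond the scatter) is the only single-point change measured to date. Compound 3 `Cc1cc(Nc2nn(Cc3ccc(S(C)(=O)=O)cc3)c(=O)c3ccccc23)n[nH]1` gives 4500 nM; set beside compound 1, the two numbers lie within the scatter.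

Compound 4 `Cc1cc(Nc2nn(Cc3cc(F)ccc3F)c(=O)c3ccccc23)n[nH]1` is not yet measured. Its change from compound 1 is 2,5-difluorobenzyl in place of 4-methoxyphenyl on an aromatic nitrogen. Two observations bear on it. The fluoro-for-methoxy exchange of a 2.3-fold lower number from compound 1 to compound 2 (0.36 log units; beyond the scatter) was modest but beyond the scatter, and compound 4 likewise carries fluorine and no methoxy. The benzyl-bearing compound 3 and compound 1 gave numbers within the scatter of one another, so a benzyl in place of a phenyl on the aromatic nitrogen is not, on its own, expected to move the number. Taken together, a modest shift toward a lower number is expected for compound 4, a 1.5-fold lower number from compound 1 to compound 4 (0.17 log units; within the scatter), with a wide range given the single relevant step. The estimate for compound 4 is 2500 nM, between 1000 nM and 7000 nM.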

Compound 4, half-maximal inhibitory concentration: 3800 nM
Compound 4: middle estimate off by 1.5-fold (0.18 log units), on the low side; measured number inside the range.
By their numbers in this assay, from the lowest: compound 2; then compounds 1, 4 and 3 (each within the scatter of the next).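

In this assay, 2,5-difluorobenzyl in place of 4-methoxyphenyl on an aromatic nitrogen gives a 1.0-fold higher number from compound 1 to compound 4 (0.01 log units; within the scatter), so carrying fluorine and no methoxy on this group is not enough to give a lower number. Against 4-fluorophenyl, the same 2,5-difluorobenzyl gives a 2.4-fold higher number from compound 2 to compound 4 (0.38 log units; beyond the scatter), so among compounds 1, 2 and 4 the lower number goes with the 4-fluorophenyl of compound 2 and not with fluorine as such. Nothing available explains this difference.

From the compounds shown here alone, whether a 4-fluorobenzyl group on this nitrogen would follow 4-fluorophenyl or 2,5-difluorobenzyl remains open, so the phenyl-to-benzyl change cannot yet be separated from the change in fluorine substitution. Also open, going by these compounds, is how a longer chain ending in an amine or a carboxylic acid would behave at this position.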